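Swapping a Hydrazone for a Propyl Amide

The source may hold more compounds than are shown below. What is called first, only, known or untested is meant among the compounds shown, and "the series" means these compounds.

In a functional assay on HepG2 cells (Homo sapiens) for antiproliferative activity, read by MTT assay (a lower number here means a stronger inhibitor, a higher number a weaker inhibitor), compound 2 `Nc1c(C(=O)N/N=C/c2ccc(Br)cc2)oc2nc(-c3ccccc3)cc(C(F)(F)F)c12` gives 19900 nM, the lowest of the two numbers seen so far; compound 1 `CCNC(=O)c1oc2nc(-c3ccccc3)cc(C(F)(F)F)c2c1N` gives 42800 nM. The change to compound 3 `CCCNC(=O)c1oc2nc(-c3ccccc3)cc(C(F)(F)F)c2c1N` is a group of 3 heavy atoms (3 carbon; no ring) in place of a group of 9 heavy atoms (7 carbon, 1 nitrogen, 1 bromine; one six-membered aromatic ring of carbon only), on an amide-type nitrogen. Within the data shown here, the only step available, a 2.2-fold lower number from compound 1 to compound 2 (0.33 log units; beyond the scatter), runs in the opposite direction: adding that ring-bearing group to the ethyl amide lowered the number. Removing it again and leaving a propyl chain, which resembles compound 1 more than compound 2, is therefore expected to raise the number by a 2.0-fold higher number from compound 2 to compound 3 (0.30 log units; within the scatter). Compound 3 is estimated at 40000 nM, with a likely range from 15000 nM to 100000 nM.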

Compound 3, half-maximal inhibitory concentration: 37400 nM
Beside the measured number, compound 3's estimate is 1.1-fold (0.03 log units) above it; the measured number falls inside the stated range.
By their numbers in this assay, from the lowest: compounds 2, 3 and 1 (each within the scatter of the next, the first and the last beyond it).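

In this assay, a propyl chain on the amide-type nitrogen and the much larger ring-bearing group of compound 2 cannot be told apart, with a 1.9-fold higher number from compound 2 to compound 3 (0.27 log units; within the scatter) lying within the scatter. The added methyl on the chain also leaves the numbers unseparated, at a 1.1-fold lower number from compound 1 to compound 3 (0.06 log units; within the scatter), so only compound 1 and compound 2 remain apart beyond the scatter. No measured evidence bears on why these numbers fall as they do.

From the compounds shown here alone, whether a longer chain such as butyl would separate from propyl remains open. So does the effect of an amine or a carboxylic acid at the end of the propyl chain.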